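The source may hold more compounds than are shown below. What is called first, only, known or untested is meant among the compounds shown, and "the series" means these compounds.

Compound 2, `Cc1ncc([N+](=O)[O-])n1CCSc1nnc(-c2ccccc2O)o1`, gives 28300 nM in a functional assay on MCF7 cells (Homo sapiens) for cytotoxicity, read by MTT assay, with a stated time of 48 h; a lower number here means a stronger inhibitor, a higher number a weaker inhibitor. For the measured compounds named here, it holds the highest of the two numbers so far; its nearest neighbour is compound 1, `COc1ccc(-c2nnc(SCCn3c([N+](=O)[O-])cnc3C)o2)cc1`, which in this assay gives 10600 nM, a step of a 2.7-fold higher number from compound 1 to compound 2 (0.43 log units; beyond the scatter). Compound 3, `Cc1ncc([N+](=O)[O-])n1CCSc1nnc(-c2ccncc2)o1`, is not yet measured. The change from compound 2: pyridin-4-yl in place of 2-hydroxyphenyl on an aromatic carbon. Going by the values given here, only the step from compound 1 to compound 2 bears on it, a modest step at the same place with different groups, so no firm direction is expected for compound 3 beyond the scatter, estimated as a 1.4-fold lower number from compound 2 to compound 3 (0.15 log units; within the scatter). The expected value for compound 3 is 20000 nM, estimated between 7000 nM and 60000 nM.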

Compound 3, half-maximal inhibitory concentration: 12600 nM
Compound 3: the middle estimate sits 1.6-fold (0.20 log units) above what was measured; the range from low to high includes it.
By their numbers in this assay, from the lowest: compounds 1 and 3 (each within the scatter of the next); then compound 2.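

In this assay, pyridin-4-yl at this position gives a 2.2-fold lower number from compound 2 to compound 3 (0.35 log units; beyond the scatter) and, set against 4-methoxyphenyl, gives a 1.2-fold higher number from compound 1 to compound 3 (0.08 log units; within the scatter) so these two groups cannot be told apart here. Compound 2, with 2-hydroxyphenyl, now stands apart from both others beyond the scatter, and a ring of carbon only is not needed to reach the level of compound 1. No measurement on hand gives a reason for these steps. Open, going by these compounds, is whether 4-hydroxyphenyl would read like 4-methoxyphenyl or like 2-hydroxyphenyl, and how a saturated amine such as piperidin-4-yl would read at this place.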